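Azetidin-1-yl to 3-methylpiperazin-1-yl: cytotoxicity outlook

This account rests on a few compounds, and the source may have more. Where it says the series, first, only, none or still open, it means among the compounds named here.

Compound 1, `Cc1ccc2c(NCc3ccc(NC(=O)C4CCN(Cc5ccccc5)CC4)cc3)nc(N3CCC3)nc2c1`, gives a limit of > 8500 nM in a functional assay on SV5A8 cells (Homo sapiens) for cytotoxicity; on this read-out higher numbers stand for weaker inhibition and lower numbers for stronger inhibition. Compound 2, `Cc1ccc2c(NCc3ccc(NC(=O)C4CCN(Cc5ccc(Cl)cc5)CC4)cc3)nc(N(C)C)nc2c1`, gives a limit of > 3180 nM in this assay. Compound 3, `CCCCN1CCC(C(=O)Nc2ccc(CNc3nc(N(C)C)nc4cc(C)ccc34)cc2)CC1`, gives a limit of > 10500 nM in this assay.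

Every number here is a limit of the assay rather than a measured value, so compound 1 cannot be placed above or below the other two; it simply sits at the limit of > 8500 nM in this assay, at which 1 of the 3 values shown sits, while the others sit at the limit of > 3180 nM in this assay, at which 1 of the 3 values shown sits, and (the limit of > 10500 nM in this assay, at which 1 of the 3 values shown sits). Among the measured compounds shown here, the one comparison between neighbours, a step that the two limits leave unreadable from compound 2 to compound 3, is unreadable for the same reason.

Compound 4, `Cc1ccc2c(NCc3ccc(NC(=O)C4CCN(Cc5ccccc5)CC4)cc3)nc(N3CCN[C@@H](C)C3)nc2c1`, differs from compound 1 by 3-methylpiperazin-1-yl in place of azetidin-1-yl on an aromatic carbon. For the measured compounds named here, no measured step touches this part of the shared core, and the only step that exists, a step that the two limits leave unreadable from compound 2 to compound 3, gives no size at all. The expectation is therefore that this assay again returns a limit, with a step that the limit leaves unreadable from compound 1 to compound 4 not readable beyond the scatter. For compound 4 the estimate is 10000 nM, within 3000 nM to 35000 nM.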

Compound 4, half-maximal inhibitory concentration: > 8860 nM
Compound 4 ended at the assay's limit; the forecaster's own chance of this, stated with the estimate: 80%; the middle value does not contradict the limit.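

In this assay compound 4 gives > 8860 nM, which is a limit, and compound 1 is also known only as a limit, so the step between these two compounds cannot be read. The compounds shown leave open whether 3-methylpiperazin-1-yl in place of azetidin-1-yl changes cytotoxicity at all.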